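Dropping the methyl from the aryl group: compound 4

The source may report more compounds than this note shows. Statements on the series, on what has been measured and on what is new or still open speak of the compounds shown alone.

Measured so far in an assay on CHO cells for displacement of a labelled ligand from adenosine receptor A1 (Homo sapiens), read by scintillation counting, tested at 10 uM; on this read-out lower numbers stand for less inhibition and higher numbers for more inhibition at the one concentration tested (going by the name of the read-out):
compound 1, `CC(C)(C)Cc1c(-c2ccoc2)sc(N)c1C(=O)c1ccc(Cl)cc1`, gives 1%
compound 2, `CC(C)(C)Cc1c(-c2ccccn2)sc(N)c1C(=O)c1ccc(Cl)cc1`, gives 1%
compound 3, `Cc1cccc(-c2sc(N)c(C(=O)c3ccc(Cl)cc3)c2CC(C)(C)C)c1`, gives 1%

All three share one core and differ only in the aromatic group attached to it. Compound 3 stands level with compound 1 and compound 2 at the digits shown; none of the three shows inhibition beyond the scatter in this assay.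

The next compound, compound 4, `CC(C)(C)Cc1c(-c2ccccc2)sc(N)c1C(=O)c1ccc(Cl)cc1`, differs from compound 3 in one place: hydrogen in place of methyl on an aromatic carbon. Cut one bond further out, this reads as 3-methylphenyl to phenyl.

The measured steps that bear on it are the three swaps of the aromatic group at the same position: no change at the digits printed from compound 1 to compound 2 (within the scatter), no change at the digits printed from compound 1 to compound 3 (within the scatter) and no change at the digits printed from compound 2 to compound 3 (within the scatter). Whether the group is furan-3-yl, pyridin-2-yl or 3-methylphenyl, the read-out stays flat. Removing a single methyl from that group is a smaller change than any of these, so no step beyond the scatter is expected in this assay: no change at the digits printed from compound 3 to compound 4 (within the scatter).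

Compound 4 is therefore estimated at 1%, between -9% and 11%.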

Compound 4, a percentage reported as inhibition, at one concentration (the size of the read-out at that concentration, not a potency): 1%
For compound 4 middle estimate and measured number coincide at the digits printed; low and high end bracket the measured number.
By their numbers in this assay, from the lowest: compounds 1, 2, 3 and 4 (each within the scatter of the next).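

Across the aromatic groups at this position, this assay stays flat: hydrogen in place of methyl gives (no change at the digits printed from compound 3 to compound 4 (within the scatter)), phenyl in place of pyridin-2-yl gives (no change at the digits printed from compound 2 to compound 4 (within the scatter)), and phenyl in place of furan-3-yl gives (no change at the digits printed from compound 1 to compound 4 (within the scatter)). The earlier compounds shown here all carried either a heteroatom in the ring or a methyl on it, whereas the plain phenyl ring of compound 4 has neither, and the read-out still does not move. Nothing measured here explains this flatness.

Going by these compounds, it remains open whether any group at this position can raise the inhibition, such as a phenyl ring carrying an amine or a carboxylic acid, or a longer chain in place of the ring. Changes elsewhere on the shared core also remain untested in these compounds.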